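The compounds below may be only part of what the source reports. "The series", "measured", "known", "first", "only" and "open" are said of these compounds alone.

In a functional assay on MGC-803 cells (Homo sapiens) for inhibition, read by MTT assay, with a stated time of 72 h (a higher number here means a weaker inhibitor, a lower number a stronger inhibitor), three compounds have been measured:

Compound 1 `CCCSc1nc2nc(C)cc(N3CC[C@@H](C)[C@@H](N(C)c4ncnc5[nH]ccc45)C3)n2n1` gives 15500 nM.
Compound 2 `Cc1cc(N2CC[C@@H](C)[C@@H](N(C)c3ncnc4[nH]ccc34)C2)n2nc(SCc3ccccc3Br)nc2n1` gives 27000 nM.
Compound 3 `Cc1cc(N2CC[C@@H](C)[C@@H](N(C)c3ncnc4[nH]ccc34)C2)n2nc(SCc3ccc(F)c(Cl)c3)nc2n1` gives 52000 nM.

Compound 1 has the lowest of these three numbers, though its separation from compound 2, a 1.7-fold higher number from compound 1 to compound 2 (0.24 log units; within the scatter), is small, while the separation to compound 3, a 3.4-fold higher number from compound 1 to compound 3 (0.53 log units; beyond the scatter), is larger. Compound 4 `Cc1cc(N2CC[C@@H](C)[C@@H](N(C)c3ncnc4[nH]ccc34)C2)n2nc(SCc3ccc(F)cc3)nc2n1` has not yet been measured. It differs from compound 1 in one place: 4-fluorophenyl in place of ethyl on a saturated chain carbon bound to a sulfur. Both measured steps from compound 1 make the same kind of swap, an ethyl giving way to a substituted phenyl on the saturated chain carbon bound to sulfur, and both raised the number, one within the scatter and one modestly beyond it. A similar small rise is therefore expected for compound 4, an estimated 1.9-fold higher number from compound 1 to compound 4 (0.29 log units; within the scatter), giving an expected value of 30000 nM with a range from 14000 nM to 65000 nM.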

Compound 4, half-maximal inhibitory concentration: 11900 nM
Compound 4: the middle estimate sits 2.5-fold (0.40 log units) above what was measured, outside the stated range (below it).
By their numbers in this assay, from the lowest: compounds 4, 1, 2 and 3 (each within the scatter of the next, the first and the last beyond it).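

In this assay, exchanging ethyl for 4-fluorophenyl on the saturated chain carbon bound to a sulfur need not weaken the compound, as the step is within the scatter: a 1.3-fold lower number from compound 1 to compound 4 (0.11 log units; within the scatter). What the aromatic ring carries matters, not just its presence: hydrogen in place of chloro gives a 4.4-fold lower number from compound 3 to compound 4 (0.64 log units; beyond the scatter), and 4-fluorophenyl in place of 2-bromophenyl gives a 2.3-fold lower number from compound 2 to compound 4 (0.36 log units; beyond the scatter). No supporting evidence explains these differences.

From the compounds shown here alone, whether an unsubstituted phenyl, or an amine on the ring, would match compound 4 remains open.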